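Adding an ethyl group to compound 3

The source may hold more compounds than are shown below. What is called first, only, known or untested is meant among the compounds shown, and "the series" means these compounds.

Compound 1 `COc1cc(C2=C(c3ccc(SC)cc3)CC(O[SiH2]C(C)(C)C)C2=O)cc(OC)c1OC` gives > 100 ug/mL (a limit)
Compound 2 `COc1ccc(C2=C(c3cc(OC)c(OC)c(OC)c3)C(=O)C(OC(C)=O)C2)cc1Cl` gives 64 ug/mL
Compound 3 `COc1cc(C2=C(c3ccc(OCC(=O)O)cc3)C(O)CC2=O)cc(OC)c1OC` gives > 100 ug/mL (a limit)

All three results come from an ADME assay on DU-145 cells (Homo sapiens) for cytotoxicity, read by MTT assay, with a stated time of 72 h (on this read-out higher numbers stand for weaker inhibition and lower numbers for stronger inhibition), and only one of them is a true number. For compound 3 the result > 100 ug/mL is a limit and not a number. Going by these compounds, compound 3 thus stands with compound 1 at the limit of > 100 ug/mL in this assay, at which 2 of the 3 values shown sit, and its exact place is unknown.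

Compound 4 `CCOC(=O)COc1ccc(C2=C(c3cc(OC)c(OC)c(OC)c3)C(=O)CC2O)cc1` differs from compound 3 by one change ethyl in place of hydrogen on an oxygen next to a carbonyl group in which ethyl replaces hydrogen on an oxygen next to a carbonyl group, so carboxymethyl becomes (ethoxycarbonyl)methyl. Within the data shown here, no measured pair in this assay shows what this change does. Compound 2 at 64 ug/mL shows that a number can be reached, so a modest move towards stronger inhibition is expected. There is a real chance that compound 4 stays at the limit. The expected change is an at least 1.3-fold lower number from compound 3 to compound 4 (0.12 log units; that floor lies within the scatter) and it remains uncertain. Compound 4 is estimated at 75 ug/mL with values between 30 ug/mL and 100 ug/mL as its expected range.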

Compound 4, half-maximal inhibitory concentration: > 100 ug/mL
Compound 4 ended at the assay's limit; the forecaster's own chance of this, stated with the estimate: 45%; at least 1.3-fold (0.12 log units) between middle value and limit.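

Compound 3 and compound 4 both end at a limit in this assay and not at a number, so no step between them can be read: the limit of > 100 ug/mL in this assay, at which 3 of the 4 values shown sit.

Going by these compounds, whether ethyl in place of hydrogen on an oxygen next to a carbonyl group changes inhibition at all remains open.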